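Sulfonamide hydrazides: aryl amine replaced by acyl hydrazide

This account rests on a few compounds, and the source may have more. Where it says the series, first, only, none or still open, it means among the compounds named here.

Compound 1 `Cc1cccc(NNC(=O)c2ccc(NS(=O)(=O)c3cnc(O)nc3O)cc2)c1` is measured in a functional assay on SGC-7901 cells (Homo sapiens) for antiproliferative activity, read by MTT assay, with a stated time of 24 h (on this read-out higher numbers stand for weaker inhibition and lower numbers for stronger inhibition), and gives > 20000 nM, which is a limit of the assay and not a number. Compound 2 `Cc1cccc(NNC(=O)c2cccc(NS(=O)(=O)c3cnc(O)nc3O)c2)c1` gives > 20000 nM, also a limit. Compound 3 `Cc1ccccc1NNC(=O)c1ccccc1NS(=O)(=O)c1cnc(O)nc1O` gives > 20000 nM, again a limit. The three values share one feature: the limit of > 20000 nM in this assay, at which 3 of the 3 values shown sit. For the measured compounds named here, compound 1 therefore stands at the same limit as the other two, and no measured step between any pair is available to set the size or direction of a change. Compound 4 `O=C(NNC(=O)c1cccc(Cl)c1)c1ccc(NS(=O)(=O)c2cnc(O)nc2O)cc1` differs from compound 1 by (3-chlorophenyl)carbonyl in place of 3-methylphenyl on an amine nitrogen. With nothing measured to rest on, the step of a number no higher from compound 1 to compound 4 (the limit leaves the size open) is expected to stay within the scatter, with compound 4 most likely at the limit again. Compound 4 is estimated at 20000 nM in this assay, within 5000 nM to 80000 nM.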

Compound 4, half-maximal inhibitory concentration: 8610 nM
The estimate for compound 4 lay 2.3-fold (0.37 log units) above the measured number; the measured number falls inside the stated range.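

On the amine nitrogen whose other neighbour is the amide-type nitrogen, (3-chlorophenyl)carbonyl in place of 3-methylphenyl gives the only value off the limit among the compounds shown, with an at least 2.3-fold lower number from compound 1 to compound 4 (0.36 log units; beyond the scatter) in this assay. This position therefore responds to a change of group, and the step is a bound whose full size stays open: the limit of > 20000 nM in this assay, at which 3 of the 4 values shown sit.

The change brings in the carbonyl and the chlorine together, and the compounds shown do not separate the two. A (3-methylphenyl)carbonyl group on this nitrogen would test the carbonyl alone.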